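A few compounds are considered here, and "the series" means these few. Any claim that something is new, unique, unknown or untested is made for them only; others in the source may bear on it.

Values in a functional assay on K562 cells (Homo sapiens) for antiproliferative activity, read by MTT assay, with a stated time of 48 h; a lower number here means a stronger inhibitor, a higher number a weaker inhibitor:
- compound 1 `CN(C)CCn1c(N)c(-c2nc3ccccc3[nH]2)c2nc(C#N)c(C#N)nc21`: 6340 nM
- compound 2 `N#Cc1nc2c(-c3nc4ccccc4[nH]3)c(N)n(CCO)c2nc1C#N`: > 50000 nM (a limit)
- compound 3 `CN(C)CCn1c(N)c(-c2nc3ccccc3n2C)c2nc(C#N)c(C#N)nc21`: > 50000 nM (a limit)

Compound 3 gives no number, only a limit. On these data alone, it stands at the limit of > 50000 nM in this assay, at which 2 of the 3 values shown sit, so how far it lies past that limit is unknown.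

The next compound, compound 4 `CCN(CC)CCCn1c(N)c(-c2nc3ccccc3n2C)c2nc(C#N)c(C#N)nc21`, differs from compound 3 by (diethylamino)methyl in place of dimethylamino on a saturated chain carbon, two bonds along the chain from an aromatic nitrogen. This is 2-(dimethylamino)ethyl giving way to 3-(diethylamino)propyl, with the methyl on the aromatic nitrogen kept.

Among the compounds with values here, two measured steps bear on this. The first is an at least 7.8-fold higher number from compound 1 to compound 3 (0.89 log units; beyond the scatter), which introduces the methyl that compound 4 retains, so this loss is expected to carry over. The second is an at least 7.8-fold higher number from compound 1 to compound 2 (0.89 log units; beyond the scatter), which changes the same chain but removes the amine, whereas compound 4 keeps an amine. As far as these compounds go, both steps end at a limit, so their true sizes remain open. Within the data shown here, no measured step varies the amine substituents or the chain length while the methyl is present.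

Little recovery is therefore expected in this assay, and any shift should be towards a lower number. The expected change is an at least 1.2-fold lower number from compound 3 to compound 4 (0.09 log units; that floor lies within the scatter), and a second limit is quite likely. Compound 4 is estimated at 40000 nM, with an expected range of 12000 nM to 80000 nM.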

Compound 4, half-maximal inhibitory concentration: 3270 nM
The estimate for compound 4 lay 12-fold (1.09 log units) above the measured number; the whole stated range lies above it.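

In this assay, the methyl on the aromatic nitrogen does not by itself rule out a measurable value, since compound 4 keeps that methyl and gives 3270 nM. Going from 2-(dimethylamino)ethyl to 3-(diethylamino)propyl gives an at least 15-fold lower number from compound 3 to compound 4 (1.18 log units; beyond the scatter), so with the methyl held constant the amine chain alone decides whether a value is reached, something the earlier compounds could not show. This step is only a floor, because compound 3 gives a limit and not a number: the limit of > 50000 nM in this assay, at which 2 of the 4 values shown sit.

The step changes chain length and the substituents on the amine together, so the compounds shown do not separate the two; a 3-(dimethylamino)propyl or a 2-(diethylamino)ethyl chain on the same methylated core would do so. Also open, on these data alone, are how the 3-(diethylamino)propyl chain behaves with hydrogen in place of the methyl on the aromatic nitrogen, and whether a ring amine such as piperidine or a longer chain carries the trend further.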